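The source may hold more compounds than are shown below. What is called first, only, known or untested is meant among the compounds shown, and "the series" means these compounds.

Working notes on the series in a functional assay on EKVX cells (Homo sapiens) for antiproliferative activity, read by sulforhodamine B assay, with a stated time of 48 h; on this read-out higher numbers stand for weaker inhibition of growth and lower numbers for stronger inhibition of growth. Two compounds carry measured values. Compound 1 `COc1ccc(OC)c(/C=C/c2nnc(Nc3ccc(Cl)cc3)o2)c1` pairs the dimethoxyphenyl vinyl unit with an oxadiazole bearing a chlorophenylamino group. In this assay compound 1 reports only a limit, > 100000 nM, and not a number. Compound 2 `COc1ccc(OC)c(/C=C/C(=O)N/N=C/c2ccc(Cl)cc2)c1` holds the same dimethoxyphenyl vinyl unit on an acylhydrazone linked to a chlorophenyl ring. In this assay compound 2 likewise reports only a limit, > 100000 nM, and not a number. No step between measured compounds can be computed here, and compound 2 stands where every shown value stands, namely (the limit of > 100000 nM in this assay, at which 2 of the 2 values shown sit).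

Compound 3 `COc1ccc(OC)c(/C=C/C(=O)N/N=C/c2ccccc2)c1` differs from compound 2 by hydrogen in place of chloro on an aromatic carbon. With both shown values sitting at the limit, no direction for this change can be read from the data, and a step beyond the scatter in either sense is not expected. Compound 3 is therefore expected to remain at the limit, with a step of a number no higher from compound 2 to compound 3 (the limit leaves the size open). The estimate for compound 3 in this assay is 100000 nM, within 40000 nM to 300000 nM.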

Compound 3, concentration for total growth inhibition: 59500 nM
For compound 3 the middle estimate is 1.7-fold (0.23 log units) above the measured one; the measured number falls inside the stated range.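

In this assay, within the data shown here, compound 3 is the first compound of the series to give a number and not a limit, which places a measurable value on the unsubstituted phenyl end of the acylhydrazone. Hydrogen in place of chloro, on the aromatic carbon para to a large group, gives an at least 1.6-fold lower number from compound 2 to compound 3 (0.22 log units; that floor lies within the scatter) and leaves the true size of the change open. Only a floor can be read, because compound 2 carries a limit and not a number: the limit of > 100000 nM in this assay, at which 2 of the 3 values shown sit.

The compounds shown carry only chloro and hydrogen at this place, so a methoxy group or an amine there would be needed to tell whether the value moves with the group on the ring or whether chloro alone stands apart. From the compounds shown here alone, whether the same change, 4-chlorophenyl to phenyl, would bring compound 1 off its limit on the oxadiazole side also stays open.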